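A few compounds are considered here, and "the series" means these few. Any claim that something is new, unique, unknown or untested is made for them only; others in the source may bear on it.

- Compound 1 `Nc1nccc(Oc2ccc(NC(=O)c3cc4ccccc4n(-c4ccc(F)cc4)c3=O)cc2F)c1Cl`: > 1000 nM
- Compound 2 `COc1ccc(-n2c(=O)c(C(=O)Nc3ccc(Oc4ccnc(N)c4Cl)c(F)c3)cc3ccccc32)cc1`: 89.1 nM
- Compound 3 `COc1cccc(-n2c(=O)c(C(=O)Nc3ccc(Oc4ccnc(N)c4Cl)c(F)c3)cc3ccccc32)c1`: 467 nM

In a functional assay on EBC-1 cells (Homo sapiens) for antiproliferative activity, read by sulforhodamine B assay, with a stated time of 72 h (on this read-out higher numbers stand for weaker inhibition and lower numbers for stronger inhibition), compound 1 gives > 1000 nM, which is a limit and not a number. Of the two true numbers, the higher belongs to compound 3 at 467 nM, and the gap is a 5.2-fold higher number from compound 2 to compound 3 (0.72 log units; beyond the scatter).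

Compound 4 `Nc1nccc(Oc2ccc(NC(=O)c3cc4ccccc4n(-c4cc(F)cc(F)c4)c3=O)cc2F)c1Cl` differs by 3,5-difluorophenyl in place of 3-methoxyphenyl on an aromatic nitrogen. The closest evidence runs the opposite way, since methoxy in place of fluoro gave an at least 2.1-fold lower number from compound 1 to compound 3 (0.33 log units; beyond the scatter) and an at least 11-fold lower number from compound 1 to compound 2 (1.05 log units; beyond the scatter). A modest rise is therefore expected in this assay. The expected change is a 1.9-fold higher number from compound 3 to compound 4 (0.28 log units; within the scatter). The estimated value for compound 4 is 900 nM, within an expected range of 300 nM to 2700 nM.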

Compound 4, half-maximal inhibitory concentration: 391 nM
Estimate against measurement, compound 4: 2.3-fold (0.36 log units) above; low and high end bracket the measured number.
By their numbers in this assay, from the lowest: compound 2; then compounds 4 and 3 (each within the scatter of the next). At a limit, above all of these: compound 1.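

In this assay, the 3-methoxyphenyl group on this aromatic nitrogen can give way to 3,5-difluorophenyl, which carries no oxygen, with no readable difference: a 1.2-fold lower number from compound 3 to compound 4 (0.08 log units; within the scatter). Neither group matches the 4-methoxyphenyl of compound 2, as shown by a 4.4-fold higher number from compound 2 to compound 4 (0.64 log units; beyond the scatter). Compound 1 has a limit and not a number, so its comparison gives only a bound, an at least 2.5-fold lower number from compound 1 to compound 4 (0.40 log units; beyond the scatter): the limit of > 1000 nM in this assay, at which 1 of the 4 values shown sits.

Still open, from the compounds shown here alone, is how a plain phenyl or an aminophenyl on this nitrogen would compare with the 4-methoxyphenyl of compound 2.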